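A few compounds are considered here, and "the series" means these few. Any claim that something is new, unique, unknown or untested is made for them only; others in the source may bear on it.

Compound 1 `O=C(/C(=C/C1CCCCC1)CCl)c1ccccc1`: 22000 nM
Compound 2 `CC(=O)OC/C(=C\C1CCCCC1)C(=O)c1ccccc1`: 21000 nM

Of the compounds shown here, two have been measured in a functional assay on WiDr cells (Homo sapiens) for inhibition, read by sulforhodamine B assay, with a stated time of 48 h; on this read-out lower numbers stand for stronger inhibition of growth and higher numbers for weaker inhibition of growth. Compound 1 gives 22000 nM, and compound 2 gives 21000 nM. Among the measured compounds shown here, the single step between them, a 1.0-fold lower number from compound 1 to compound 2 (0.02 log units; within the scatter), shows that exchanging the group on the saturated chain carbon leaves the read-out essentially unchanged. Compound 2 thus holds the lowest of the two numbers, but its nearest neighbour, compound 1, sits within the scatter, so the two compounds cannot be told apart on these data.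

Compound 3 `CCC(/C=C(\COC(C)=O)C(=O)c1ccccc1)CC` differs from compound 2 in one place: pentan-3-yl in place of cyclohexyl on a double-bonded chain carbon bound to a double-bonded chain carbon. For the measured compounds named here, no measured step touches this position; the only known step concerns the acetoxy and chloro groups and says nothing about the ring. Going by the values given here, with no direct precedent, the expectation rests on the one observation that a change elsewhere left the number where it was. Compound 3 is therefore expected to give about 25000 nM, with a plausible range from 10000 nM to 60000 nM. The estimated step, a 1.2-fold higher number from compound 2 to compound 3 (0.08 log units; within the scatter), is expected to remain within the scatter.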

Compound 3, concentration for 50% growth inhibition: 52000 nM
Beside the measured number, compound 3's estimate is 2.1-fold (0.32 log units) below it; low and high end bracket the measured number.
By their numbers in this assay, from the lowest: compounds 2 and 1 (each within the scatter of the next); then compound 3.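

In this assay, putting pentan-3-yl in place of cyclohexyl on a double-bonded chain carbon bound to a double-bonded chain carbon gives a 2.5-fold higher number from compound 2 to compound 3 (0.39 log units; beyond the scatter), a modest loss of growth inhibition. Among the compounds shown here, the earlier exchange of chloro for acetoxy gave a 1.0-fold lower number from compound 1 to compound 2 (0.02 log units; within the scatter), so this position is the first where a change moves the number beyond the scatter, and the cyclohexyl group of compound 2 cannot be swapped for this open-chain group without some cost. Nothing available bears on why the number rises at this position.

The single step removes the ring and changes the heavy-atom count together, from 6 carbons in cyclohexyl to 5 in pentan-3-yl, so the compounds shown cannot separate the two changes. On these data alone, it also remains open how a cyclopentyl or phenyl ring, or a longer chain such as heptan-4-yl, would read at this position, and whether the step from cyclohexyl to pentan-3-yl would be the same with chloro in place of acetoxy.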